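A few compounds are considered here, and "the series" means these few. Any claim that something is new, unique, unknown or untested is made for them only; others in the source may bear on it.

Compound 1 `O=C1CCC(c2ccc(NC(=O)CCl)cc2)=NN1` is the reference point here. In a functional assay for inhibition, with Homo sapiens as the target (a lower number here means that less compound is needed, a higher number that more compound is needed for the effect), compound 1 gives 0.39 ug/mL, the lowest of the two numbers available, with compound 3 as its nearest neighbour. Compound 3 `CC1CC(c2ccc(NC(=O)CCl)cc2)=NNC1=O` gives 21.9 ug/mL. Compound 2 `CN1N=C(c2ccc(NC(=O)CCl)cc2)CCC1=O` gives only a limit in this assay, > 46.4 ug/mL, which is not a number (the limit of > 46.4 ug/mL in this assay, at which 1 of the 3 values shown sits). The two measured steps both alter the core: an at least 110-fold higher number from compound 1 to compound 2 (2.07 log units; beyond the scatter) and a 56-fold higher number from compound 1 to compound 3 (1.75 log units; beyond the scatter). Both are large and both point toward a higher number.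

Compound 4 `CC(C)NCC(=O)Nc1ccc(C2=NNC(=O)CC2)cc1` differs from compound 1 at a different place: isopropylamino in place of chloro on a saturated chain carbon bound to a carbonyl carbon. For the measured compounds named here, neither measured step touches this part of the molecule, so no measured step bears directly on the change. As far as these compounds go, the two steps do show that the core tolerates little alteration, while the chain carbon bound to the carbonyl carbon is untested. A higher number is expected, with wide uncertainty: compound 4 is estimated at 6 ug/mL, from 1 ug/mL to 35 ug/mL, a step of a 15-fold higher number from compound 1 to compound 4 (1.19 log units; beyond the scatter).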

Compound 4, half-maximal effective concentration: about 46.4 ug/mL
Estimate against measurement, compound 4: 7.7-fold (0.89 log units) below, outside the stated range (above it).
By their numbers in this assay, from the lowest: compound 1; then compound 3; then compound 4.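

Moving the change away from the core does not spare the activity: in this assay, isopropylamino in place of chloro on a saturated chain carbon bound to a carbonyl carbon gives a 120-fold higher number from compound 1 to compound 4 (2.08 log units; beyond the scatter). All three changes shown from compound 1, two at the core and one on the chain, therefore raise the number by a large step, and none goes against this. The figure for compound 4 also stands at the same place as a limit of this assay: the limit of > 46.4 ug/mL in this assay, at which 1 of the 4 values shown sits.

As far as these compounds go, a single swap cannot separate the loss of chloro from the arrival of isopropylamino, so it remains open which of the two counts. Bromo, a methyl group or a smaller amine such as methylamino at this place would help to tell them apart.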